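Acid-bearing aryl amides in human liver microsomes

The source may hold more compounds than are shown below. What is called first, only, known or untested is meant among the compounds shown, and "the series" means these compounds.

Compound 1, `CC(C)(C(=O)O)N1CCCN(c2ccc(F)c(C(F)(F)F)c2)C1=O`, in an ADME assay on microsomes from liver (Homo sapiens) for metabolic stability, using NADPH, with a stated time of 60 min (a lower number here means slower removal, a higher number faster removal of the compound), gives a value that is an assay limit, < 7 uL/min.
Compound 2, `CC(C)(CC(=O)Nc1ccc(F)c(C(F)(F)F)c1)C(=O)O`, in this assay also gives a value that is an assay limit, < 7 uL/min.

Neither value is a measured number; both sit at the limit of < 7 uL/min in this assay, at which 2 of the 2 values shown sit. Going by the values given here, compound 2 thus stands where the only other measured compound stands, at the floor of what this assay can report, and no step between measured compounds is available.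

Compound 3, `O=C(Nc1ccc(F)c(C(F)(F)F)c1)NC1(C(=O)O)CC1`, has not been measured. It differs from compound 2 in one place: (1-carboxycyclopropyl)amino in place of 2-carboxy-2-methylpropyl on a carbonyl carbon. The aryl amide part is kept unchanged, and a carboxylic acid remains on the side chain.

With both known compounds at the limit, the step from compound 2 to compound 3 is expected to stay within the usual scatter, a step that the limit leaves unreadable from compound 2 to compound 3. Compound 3 is estimated at 5 uL/min, within a range from 2 uL/min to 12 uL/min, most likely reported once more only as a limit.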

Compound 3, intrinsic clearance in a liver preparation (reported as CLH), per the amount of preparation that the assay uses in the Homo sapiens assay: < 7 uL/min
Compound 3 ended at the assay's limit (the forecaster's own chance of this, stated with the estimate: 65%); the middle value is on the limit's open side.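

In the Homo sapiens assay, compound 2 and compound 3 both sit at the assay's limit, and no step can be read between them. In a physicochemical assay for solubility, read by nephelometry, in phosphate buffer, measured as kinetic solubility, at pH 6.5, tested at 10 mg/mL (a higher number here means a more soluble compound, a lower number a less soluble compound), compound 2 gives 25 ug/mL. In the physicochemical assay, compound 3 gives > 100 ug/mL, which is an assay limit. The compounds shown leave open how fast each is actually removed in the Homo sapiens assay: the limit of < 7 uL/min in the Homo sapiens assay, at which 3 of the 3 values shown sit.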